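The source may hold more compounds than are shown below. What is called first, only, known or untested is meant among the compounds shown, and "the series" means these compounds.

Of the compounds shown here, three have numbers so far: compound 1 `CC[C@@H](Nc1c(C#N)c(-c2ccc(-c3cccc(Cl)c3F)cc2)nc2cnccc12)C(N)=O`, compound 2 `CC[C@@H](Nc1c(C#N)c(-c2ccc(-c3cccc(CO)c3)cc2)nc2cnccc12)C(N)=O` and compound 3 `CC[C@@H](Nc1c(C#N)c(-c2ccc(-c3ccccc3COC)cc2)nc2cnccc12)C(N)=O`; compound 4 `CC[C@@H](Nc1c(C#N)c(-c2ccc(-c3ccc(Cl)cc3)cc2)nc2cnccc12)C(N)=O` has not yet been measured. In a physicochemical assay for lipophilicity, read by HPLC, at pH 7.5 (a lower number here means a more polar compound, a higher number a more lipophilic compound), compound 1 gives 3.1, compound 2 gives 2 and compound 3 gives 2.6. Compound 3 thus stands second highest of the three, nearest to compound 1 and furthest from compound 2. The next step is 4-chlorophenyl in place of 2-(methoxymethyl)phenyl on an aromatic carbon. The step bearing on it most directly is a number 0.50 log units lower from compound 1 to compound 3 (beyond the scatter); run back towards a ring carrying chlorine, it points upward, and a number 0.60 log units higher from compound 2 to compound 3 (beyond the scatter) together with a number 1.10 log units lower from compound 1 to compound 2 (beyond the scatter) fits the same ordering. A modest rise beyond the scatter is therefore expected, a number 0.40 log units higher from compound 3 to compound 4 (beyond the scatter). Compound 4 is estimated at 3, within 2.7 to 3.4.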

Compound 4, distribution coefficient: 3.1
Beside the measured number, compound 4's estimate is 0.10 log units below it; the range from low to high includes it.
By their numbers in this assay, from the lowest: compound 2; then compound 3; then compounds 1 and 4 (each within the scatter of the next).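

In this assay 4-chlorophenyl on this aromatic carbon gives a number 0.50 log units higher from compound 3 to compound 4 (beyond the scatter) and a number 1.10 log units higher from compound 2 to compound 4 (beyond the scatter) so, among the compounds shown, both rings carrying chlorine read above both rings carrying an oxygen-containing chain. The result no change at the digits printed from compound 1 to compound 4 (within the scatter) leaves 4-chlorophenyl and 3-chloro-2-fluorophenyl unseparated, so the second halogen and the different chlorine placement give no readable step in this pair. No available evidence accounts for this ordering. On these data alone, whether an amine or a carboxylic acid on this ring would fall below 3-(hydroxymethyl)phenyl remains open. So does the position of unsubstituted phenyl relative to the chlorine-bearing rings.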